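Pyrrolidine to tetrahydroisoquinoline on a shared aminopyrimidine core

The compounds below may be only part of what the source reports. "The series", "measured", "known", "first", "only" and "open" are said of these compounds alone.

Of the compounds shown here, three have been tested in a functional assay on MDA-MB-231 cells (Homo sapiens) for inhibition, read by MTT assay, with a stated time of 72 h, tested at 20 uM; on this read-out lower numbers stand for less inhibition and higher numbers for more inhibition at the one concentration tested (going by the name of the read-out). Compound 1 `CNC(=O)c1cc(Oc2ccc(Nc3nccc(N4CCCC4)n3)cc2)ccn1` gives 46.6%. Compound 2 `CN(C)c1ccc(C(=O)Nc2ccc(Oc3ncnc4ccsc34)cc2)cc1` gives 10.4%. Compound 3 `CN(c1ccc(Oc2ncnc3ccsc23)cc1)c1nccc(N2CCCC2)n1` gives 38%. Among these three numbers compound 3 stands second highest; its nearest neighbour is compound 1, whose number is within the scatter of that of compound 3, so no order between the two can be read. Its furthest neighbour is compound 2, whose number is lower by a gap beyond the scatter.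

Compound 4 `CN(c1ccc(Oc2ncnc3ccsc23)cc1)c1nccc(N2CCc3ccccc3C2)n1` has not yet been tested in this assay. It differs from compound 3 in one place: 1,2,3,4-tetrahydroisoquinolin-2-yl in place of pyrrolidin-1-yl on an aromatic carbon. Within the data shown here, no measured pair shows what this change does, so the expectation rests on the spread of the three numbers alone. The step from compound 3 to compound 4 is expected to be small, a number 4 percentage points higher from compound 3 to compound 4 (within the scatter), with no clear direction beyond the scatter. On that basis compound 4 is estimated to give 42% in this assay, within a range from 18% to 68%.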

Compound 4, a percentage reported as inhibition, at one concentration (the size of the read-out at that concentration, not a potency): 30.2%
For compound 4 the middle estimate is 11.8 percentage points above the measured one; measured number inside the range.
By their numbers in this assay, from the lowest: compound 2; then compounds 4, 3 and 1 (each within the scatter of the next, the first and the last beyond it).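

In this assay, among these compounds, the first measured change at this position gives a number 7.8 percentage points lower from compound 3 to compound 4 (within the scatter). The position, on an aromatic carbon next to the ring nitrogen, therefore takes 1,2,3,4-tetrahydroisoquinolin-2-yl, with its added six-membered aromatic ring of carbon only, in place of pyrrolidin-1-yl without a change that can be told from the scatter. This rests on a single pair at a single concentration, so it shows that this one swap leaves the read-out within the usual spread, not that every other group at the position would do the same. No measurement shown here offers an explanation for this step.

As far as these compounds go, whether a morpholin-4-yl ring or an open-chain amine such as dimethylamino at this position would move the number beyond the scatter remains open. So does whether the same swap would behave alike on the core of compound 1.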